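A few compounds are considered here, and "the series" means these few. Any claim that something is new, unique, unknown or untested is made for them only; others in the source may bear on it.

Compound 1 `COc1ccc2sc(NC(=O)c3cc(=O)c4ccccc4o3)nc2c1` gives 390 nM
Compound 2 `O=C(Nc1nc(-c2ccc(F)cc2)cs1)c1cc(=O)c2ccccc2o1` gives 440 nM

In a functional assay on SK-OV-3 cells (Homo sapiens) for antiproliferative activity, read by CCK-8 assay, with a stated time of 48 h (a lower number here means a stronger inhibitor, a higher number a weaker inhibitor), compound 1 gives 390 nM and compound 2 gives 440 nM so the two stand within the scatter of each other, and compound 1 has no clear lead. Compound 3 `O=C(Nc1nc2cc(F)ccc2s1)c1cc(=O)c2ccccc2o1` has fluoro in place of methoxy on an aromatic carbon of the core of compound 1. Within the data shown here, no measured pair shows this change, so in this assay only a modest step toward a higher number is expected, perhaps not far beyond the scatter. Compound 3 is estimated at 600 nM with a range from 200 nM to 1800 nM as its likely span. This means an expected step of a 1.5-fold higher number from compound 1 to compound 3 (0.19 log units; within the scatter) of modest size.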

Compound 3, half-maximal inhibitory concentration: 420 nM
Estimate against measurement, compound 3: 1.4-fold (0.15 log units) above; measured number inside the range.
By their numbers in this assay, from the lowest: compounds 1, 3 and 2 (each within the scatter of the next).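

In this assay, fluoro in place of methoxy on an aromatic carbon of the core gives a 1.1-fold higher number from compound 1 to compound 3 (0.03 log units; within the scatter). Among these compounds, this is the first matched pair at this position, and it shows that the smaller fluoro and the methoxy cannot be told apart here, despite the loss of a hydrogen-bond acceptor. Nothing available explains why the two groups read alike.

On these data alone, whether an amine or a carboxylic acid on this aromatic carbon would also stay within the scatter remains open. So does the outcome for a longer chain, such as ethoxy, at this position.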